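A few compounds are considered here, and "the series" means these few. Any claim that something is new, unique, unknown or untested is made for them only; others in the source may bear on it.

Three compounds share a core in which a sulfur-containing ring is fused to an aromatic ring carrying a methyl group and an acylguanidine. Compound 1 `C=C1CCS(=O)(=O)c2cc(C(=O)N=C(N)N)c(C)cc21` carries a double bond to carbon on the saturated ring; compound 2 `Cc1cc2c(cc1C(=O)N=C(N)N)S(=O)(=O)CCC2C` carries a methyl group there; compound 3 `Cc1cc2c(cc1C(=O)N=C(N)N)S(=O)(=O)CC2(O)C(=O)c1ccccc1` carries both a hydroxyl and a benzoyl group on one saturated ring carbon. In an assay on cells for inhibition of sodium/hydrogen exchanger (Oryctolagus cuniculus) (a lower number here means a stronger inhibitor, a higher number a weaker inhibitor), compound 1 gives 29 nM, compound 2 gives 45 nM, and compound 3 gives 43 nM. Compound 3 stands second highest of the three numbers, but its nearest neighbour, compound 2, and its furthest, compound 1, both lie within the usual scatter of it, so the three substitution patterns on the saturated ring cannot be told apart on these numbers.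

Compound 4 `Cc1cc2c(cc1C(=O)N=C(N)N)S(=O)(=O)CC2O` keeps the hydroxyl group and differs from compound 3 by hydrogen in place of benzoyl on a saturated ring carbon, leaving a smaller group on that carbon. Going by the values given here, no measured pair differing in one place is available, so the expectation rests on the observation that compounds 1, 2 and 3 give numbers within the scatter of one another. The step from compound 3 to compound 4 is therefore expected to be a 1.1-fold lower number from compound 3 to compound 4 (0.03 log units; within the scatter), that is, nothing beyond the scatter. Compound 4 is expected to give 40 nM, with a range from 15 nM to 120 nM.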

Compound 4, half-maximal inhibitory concentration: 70 nM
Compound 4: the middle estimate sits 1.8-fold (0.24 log units) below what was measured; low and high end bracket the measured number.
By their numbers in this assay, from the lowest: compounds 1, 3, 2 and 4 (each within the scatter of the next, the first and the last beyond it).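

In this assay, going by these compounds alone, putting hydrogen in place of benzoyl on this saturated ring carbon gives a 1.6-fold higher number from compound 3 to compound 4 (0.21 log units; within the scatter), and this is the first comparison here between two compounds that differ in only one place. The change removes 8 heavy atoms, including a six-membered aromatic ring and a hydrogen-bond acceptor, yet compound 3 and compound 4 cannot be told apart, so these numbers show neither that benzoyl is needed on this carbon nor that it does harm. No other measurement here bears on why so large a structural change leaves the number within the scatter.

The hydroxyl group is present in both compound 3 and compound 4, so its own contribution remains open, as no compound shown has hydrogen in its place while everything else stays the same. Also open, on these data alone, is whether this carbon would accept groups of other kinds alongside the hydroxyl, such as an amine, a carboxylic acid or a longer alkyl chain, since benzoyl and hydrogen are the only two compared here.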